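Chlorobenzyl thioether series: ring substitution pattern and vasodilation

This account rests on a few compounds, and the source may have more. Where it says the series, first, only, none or still open, it means among the compounds named here.

Of the compounds shown here, three have been measured in a functional assay on the whole organism (artery, strain albino) with Rattus norvegicus as the target, with a stated time of 180 min, at a dose of 10 mg/kg by the oral route; a higher number here means more inhibition at the dose given (going by the name of the read-out), a lower number less inhibition. Compound 1 `COc1ccc(C2N=C(SCc3cccc(Cl)c3)NC(C)=C2C(=O)Nc2ccc(F)cc2)cc1OC` gives 13.4%. Compound 2 `COc1ccc(C2N=C(SCc3ccc(Cl)cc3)NC(C)=C2C(=O)Nc2ccc(F)cc2)cc1OC` gives 20.1%. Compound 3 `CC1=C(C(=O)Nc2ccc(Br)cc2)C(c2ccc(Cl)cc2Cl)N=C(SCc2cccc(Cl)c2)N1` gives 11.9%. Compound 1 and compound 2 differ by 4-chlorophenyl in place of 3-chlorophenyl on a saturated chain carbon bound to a sulfur, and the step that this change makes is a number 6.7 percentage points higher from compound 1 to compound 2 (within the scatter). The difference between the core of compound 1 and the core of compound 3 is not broken down here. The values of compound 3 and compound 1 lie within the scatter of each other, as do those of compound 3 and compound 2, so no order among the three can be read from these numbers.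

Compound 4 `CC1=C(C(=O)Nc2ccc(Br)cc2)C(c2ccc(Cl)cc2Cl)N=C(SCc2ccc(Cl)cc2)N1` has not yet been measured. It differs from compound 3 by 4-chlorophenyl in place of 3-chlorophenyl on a saturated chain carbon bound to a sulfur, the same change, at the same place, as that made from compound 1 to compound 2.

The expectation for compound 4 rests on the single shown step, namely a number 6.7 percentage points higher from compound 1 to compound 2 (within the scatter) from compound 1 to compound 2, applied to the value of compound 3 11.9%. Going by the values given here, the step from compound 3 to compound 4 is estimated at a number 5.1 percentage points higher from compound 3 to compound 4 (within the scatter), a shift that, like the one seen between compound 1 and compound 2, is expected to stay within the scatter of this assay. Compound 4 is therefore expected to give 17%, with a range from 7% to 28%. Among the compounds with values here, with only one prior example of this change, and that one within the scatter, the estimate carries wide uncertainty.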

Compound 4, a percentage reported as inhibition, in the whole organism at one dose (the size of the read-out at that dose, not a potency): 23.2%
For compound 4 the middle estimate is 6.2 percentage points below the measured one; the range from low to high includes it.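

On the core of compound 3, 4-chlorophenyl in place of 3-chlorophenyl on a saturated chain carbon bound to a sulfur gives a number 11.3 percentage points higher from compound 3 to compound 4 (beyond the scatter) in this assay. Going by these compounds alone, only this step clears the scatter, and its size cannot be told apart from that of the same change on the core of compound 1: the same change on two cores in this assay, a number 6.7 percentage points higher (within the scatter) from compound 1 to compound 2 and a number 11.3 percentage points higher (beyond the scatter) from compound 3 to compound 4, 4.6 percentage points apart, within the scatter of two such steps. The two pairs are thus consistent with the change carrying over between these two cores with no visible dependence on the core, but the step on the core of compound 1 would not establish an effect on its own, and two pairs give no rule for any other core in the series.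

Every sulfur substituent shown is a chlorobenzyl group, which leaves open what a plain benzyl, a methoxybenzyl or a longer chain such as phenethyl would give on either core. Within the data shown here, also open is how much the other parts of the cores contribute, as compound 1 and compound 3 differ in more than one place, and the readings at a single oral dose give no potency for any compound.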